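A few compounds are considered here, and "the series" means these few. Any claim that something is new, unique, unknown or untested is made for them only; others in the source may bear on it.

Compound 1 `CC(C)c1ccc(S(=O)(=O)N2CCN(C(C)C(=O)N3CCCC3)CC2)cc1`, compound 2 `CCC(C)c1ccc(S(=O)(=O)N2CCN(C(C)C(=O)N3CCCC3)CC2)cc1` and compound 3 `CC(C(=O)N1CCCC1)N1CCN(S(=O)(=O)c2ccc([Si](C)(C)C)cc2)CC1` share one core and were each tested in an ADME assay on HepG2 cells (Homo sapiens) for inhibition, with a stated time of 48 h; on this read-out lower numbers stand for an effect already at smaller amounts and higher numbers for an effect only at larger amounts of compound. For compound 1 the read-out is only a limit of the assay, > 40000 nM. For compound 2 the read-out is likewise a limit, > 40000 nM. Compound 3 also stands only at a limit, > 40000 nM. The steps a step that the two limits leave unreadable from compound 1 to compound 2, a step that the two limits leave unreadable from compound 1 to compound 3 and a step that the two limits leave unreadable from compound 2 to compound 3 therefore cannot be read, since (the limit of > 40000 nM in this assay, at which 3 of the 3 values shown sit). Compound 4 `CC(C(=O)N1CCCC1)N1CCN(S(=O)(=O)c2ccc(C(C)(C)CO)cc2)CC1` carries a group of 5 heavy atoms (4 carbon, 1 oxygen; no ring) in place of a group of 4 heavy atoms (3 carbon, 1 silicon; no ring), on an aromatic carbon. Within the data shown here, no measured step bears on this change, and with every value at the limit no shift beyond the scatter in this assay is expected. Compound 4 is estimated at 50000 nM, within 20000 nM to 150000 nM. The expected step is a step that the limit leaves unreadable from compound 3 to compound 4, leaving it at the limit as well.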

Compound 4, half-maximal effective concentration: > 40000 nM
Compound 4 ended at the assay's limit; the forecaster's own chance of this, stated with the estimate: 85%; the middle value does not contradict the limit.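

The steps to compound 4 from compound 1, compound 2 and compound 3 cannot be read, because all four compounds stand at the same limit: the limit of > 40000 nM in this assay, at which 4 of the 4 values shown sit.

The compounds shown leave open how far these groups on the aromatic carbon differ in effect, if they differ at all.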